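This account rests on a few compounds, and the source may have more. Where it says the series, first, only, none or still open, it means among the compounds named here.

Measured so far in a functional assay on mitochondria from heart for inhibition of peroxisomal acyl-coenzyme A oxidase 1 (Rattus norvegicus); a higher number here means a weaker inhibitor, a lower number a stronger inhibitor:
- compound 1 `Cc1nc2cc(OC[C@H](O)CN3CCN(Cc4noc(-c5ccc(C(C)C)cc5)n4)CC3)ccc2s1` gives 950 nM
- compound 2 `Cc1cccc(-c2nc(CN3CCN(C[C@@H](O)COc4ccc5sc(C)nc5c4)CC3)no2)c1` gives 6500 nM
- compound 3 `Cc1nc2cc(OC[C@H](O)CN3CCN(Cc4noc(-c5cccc(Cl)c5)n4)CC3)ccc2s1` gives 4120 nM

All three share the same core and differ only in the substituted phenyl ring at one end. Compound 3 stands second highest of the three numbers in this assay. Its closest neighbour is compound 2: the step of a 1.6-fold lower number from compound 2 to compound 3 (0.20 log units; within the scatter) is within the scatter, so the two cannot be told apart. The step of a 4.3-fold higher number from compound 1 to compound 3 (0.64 log units; beyond the scatter) is beyond the scatter, as is a 6.8-fold higher number from compound 1 to compound 2 (0.84 log units; beyond the scatter), so compound 1 is clearly the stronger inhibitor of the set.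

Compound 4 `Cc1nc2cc(OC[C@H](O)CN3CCN(Cc4noc(-c5cccc(F)c5)n4)CC3)ccc2s1` differs from compound 3 by fluoro in place of chloro on an aromatic carbon. Among the compounds with values here, the only measured step at this same position is a 1.6-fold lower number from compound 2 to compound 3 (0.20 log units; within the scatter), an exchange of one small group for another that stayed within the scatter. Larger shifts appeared only when the whole phenyl substitution pattern changed, as in a 4.3-fold higher number from compound 1 to compound 3 (0.64 log units; beyond the scatter). A small single-atom exchange at an already-occupied position is therefore expected to give a step of no more than the scatter, with no clear direction. Compound 4 is expected to give about 5500 nM in this assay, between 2500 nM and 12000 nM, a step of a 1.3-fold higher number from compound 3 to compound 4 (0.13 log units; within the scatter).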

Compound 4, half-maximal inhibitory concentration: 13400 nM
Compound 4: the middle estimate sits 2.4-fold (0.39 log units) below what was measured; the whole stated range lies below it.
By their numbers in this assay, from the lowest: compound 1; then compounds 3 and 2 (each within the scatter of the next); then compound 4.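

The aromatic carbon meta to a large group proves sensitive to a one-atom exchange: fluoro in place of chloro weakens inhibition by a step beyond the scatter (a 3.3-fold higher number from compound 3 to compound 4 (0.51 log units; beyond the scatter)). Within the data shown here, the earlier exchange at this carbon, chloro in place of methyl, stayed within the scatter, so this is the first sign that the choice of small group here matters, and fluoro also separates from methyl (a 2.1-fold higher number from compound 2 to compound 4 (0.31 log units; beyond the scatter)). The gap to the 4-isopropylphenyl compound now becomes large (a 14-fold higher number from compound 1 to compound 4 (1.15 log units; beyond the scatter)), and no measurement shown accounts for any of these steps.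

Open, from the compounds shown here alone, is whether a methoxy group or a nitrile at this carbon would match chloro and methyl or fall with fluoro. Also open, going by these compounds, is whether the lower number of compound 1 follows from the isopropyl group itself or from where it sits, which 3-isopropylphenyl and 4-chlorophenyl partners would separate.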